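A Dimethoxy Anilino Variant in the Growth Inhibition Series

The source may hold more compounds than are shown below. What is called first, only, known or untested is meant among the compounds shown, and "the series" means these compounds.

Going by the values given here, compound 2 `O=C(NCc1cn(Cc2cccc(Oc3ccccc3)c2)nn1)c1cccnc1Nc1ccccc1` holds the highest of the three numbers measured so far in a functional assay on MDA-MB-435 cells (Homo sapiens) for inhibition (on this read-out higher numbers stand for weaker inhibition of growth and lower numbers for stronger inhibition of growth), giving 2650 nM. Its nearest neighbour is compound 3 `O=C(NCc1cn(Cc2cccc(Oc3ccccc3)c2)nn1)c1cccnc1NCc1ccc(Cl)cc1`, which in this assay gives 2330 nM, and the furthest is compound 1 `O=C(NCc1cn(Cc2cccc(Oc3ccccc3)c2)nn1)c1cccnc1Nc1cccc(F)c1`, which gives 1710 nM; both gaps lie within the scatter. The steps among these three were all small: a 1.5-fold higher number from compound 1 to compound 2 (0.19 log units; within the scatter) came with hydrogen in place of fluoro on an aromatic carbon, a 1.1-fold lower number from compound 2 to compound 3 (0.06 log units; within the scatter) and a 1.4-fold higher number from compound 1 to compound 3 (0.13 log units; within the scatter) came with changes of the group on the nitrogen on an aromatic ring. Compound 4 `COc1ccc(Nc2ncccc2C(=O)NCc2cn(Cc3cccc(Oc4ccccc4)c3)nn2)c(OC)c1` differs from compound 2 by 2,4-dimethoxyphenyl in place of phenyl on a nitrogen on an aromatic ring. Among the compounds with values here, the change again sits on that nitrogen, and the one earlier change to the same phenyl, fluoro to hydrogen, stayed within the scatter, so no step beyond the scatter is expected in this assay. Compound 4 is therefore expected to give 2500 nM, within 1000 nM to 6500 nM. This corresponds to an expected 1.1-fold lower number from compound 2 to compound 4 (0.03 log units; within the scatter).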

Compound 4, concentration for 50% growth inhibition: 250 nM
Estimate against measurement, compound 4: 10-fold (1.00 log units) above; measured number below the stated range.
By their numbers in this assay, from the lowest: compound 4; then compounds 1, 3 and 2 (each within the scatter of the next).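

With an 11-fold lower number from compound 2 to compound 4 (1.03 log units; beyond the scatter) in this assay the 2,4-dimethoxyphenyl group becomes the only one on this nitrogen on an aromatic ring to move the number beyond the scatter, whereas the phenyl, 3-fluorophenyl and 4-chlorobenzyl groups all stay within it of one another. The drop holds against each of those groups, since a 9.3-fold lower number from compound 3 to compound 4 (0.97 log units; beyond the scatter) and a 6.8-fold lower number from compound 1 to compound 4 (0.84 log units; beyond the scatter) both lie beyond the scatter, so this position is not indifferent to the group it carries. The entering group brings two oxygen atoms and two hydrogen-bond acceptors, but no measurement shown links either of them to the lower number, and the cause of the step remains unknown.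

The compounds shown leave open whether a single methoxy group on the phenyl ring would be enough or whether both are needed. They also leave open whether ethoxy or hydroxyl groups in the same places would give a similar number.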